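Aryl ether variation on the shared core

The compounds below may be only part of what the source reports. "The series", "measured", "known", "first", "only" and "open" are said of these compounds alone.

Compound 2 `CNC(=O)c1cccc(NC(=O)N2CCC(Oc3ccccc3C)CC2)c1` gives 17 nM in an assay on isolated protein for inhibition of acyl-CoA desaturase 1 (Mus musculus) (on this read-out lower numbers stand for stronger inhibition and higher numbers for weaker inhibition), and holds the lowest of the two plain numbers in this set; its nearest measured neighbour, compound 3 `CNC(=O)c1cccc(NC(=O)N2CCC(Oc3c(F)cccc3Cl)CC2)c1`, gives 330 nM in this assay. Compound 1 `CNC(=O)c1cccc(NC(=O)N2CCC(Oc3ccccc3Br)CC2)c1` is reported in this assay only as a limit, < 4 nM (the limit of < 4 nM in this assay, at which 1 of the 3 values shown sits). Compound 4 `CNC(=O)c1cccc(NC(=O)N2CCC(Oc3ccc(F)cc3Cl)CC2)c1` differs from compound 2 by 2-chloro-4-fluorophenyl in place of 2-methylphenyl on an oxygen on a saturated carbon. Going by the values given here, two measured steps bear on this. The step of a 19-fold higher number from compound 2 to compound 3 (1.29 log units; beyond the scatter) introduces chloro and fluoro into the same ring, but as 2-chloro-6-fluorophenyl rather than the 2-chloro-4-fluorophenyl of compound 4. The step of an at least 4.2-fold higher number from compound 1 to compound 2 (0.62 log units; beyond the scatter) shows that a halogen in place of methyl on that ring gave the lower number, and an at least 82-fold higher number from compound 1 to compound 3 (1.91 log units; beyond the scatter) marks the full span seen so far. Compound 4 carries a chloro as compound 3 does, yet its fluoro stands in the 2-chloro-4-fluorophenyl pattern, so a number between those of compound 2 and compound 3 is expected. For compound 4 the expected step is a 1.8-fold higher number from compound 2 to compound 4 (0.25 log units; within the scatter). The estimate for compound 4 is 30 nM, within 6 nM to 150 nM.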

Compound 4, half-maximal inhibitory concentration: 6 nM
Compound 4: middle estimate off by 5.0-fold (0.70 log units), on the high side; the measured number falls inside the stated range.
By their numbers in this assay, from the lowest: compound 4; then compound 2; then compound 3. At a limit, below all of these: compound 1.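

The step of a 55-fold lower number from compound 3 to compound 4 (1.74 log units; beyond the scatter) in this assay joins two aryl groups carrying the same halogens, so the higher number of compound 3 belongs to the 2-chloro-6-fluorophenyl pattern and not to chloro and fluoro together. The 2-chloro-4-fluorophenyl group also gives a lower number than 2-methylphenyl, with a 2.8-fold lower number from compound 2 to compound 4 (0.45 log units; beyond the scatter) as a modest step. Compound 1 stands only as a limit: the limit of < 4 nM in this assay, at which 1 of the 4 values shown sits. With that limit, the step of an at least 1.5-fold higher number from compound 1 to compound 4 (0.17 log units; that floor lies within the scatter) cannot be read as a difference.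

On these data alone, the separate shares of the chloro and the fluoro remain open, as neither 2-chlorophenyl nor 4-fluorophenyl stands alone in this set. Also open, as far as these compounds go, is how this aryl ether would read with a methoxy, a nitrile or a carboxylic acid on the ring.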